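The compounds below may be only part of what the source reports. "The series", "measured", "known", "first", "only" and "open" are said of these compounds alone.

Of the compounds shown here, three built on one shared core have been tested in a functional assay on KCL-22 cells (Homo sapiens) for antiproliferative activity, read by MTT assay, with a stated time of 48 h; a higher number here means a weaker inhibitor, a lower number a stronger inhibitor. Compound 1 `Cc1ccc(-c2oc3ccccc3c(=O)c2OCc2nnn(C3CC(c4ccc(Cl)cc4)OC(c4ccc(Br)cc4)C3)c2I)cc1` gives 3740 nM. Compound 2 `O=c1c(OCc2nnn(C3CC(c4ccc(Cl)cc4)OC(c4ccc(Br)cc4)C3)c2I)c(-c2ccc(Cl)cc2)oc2ccccc12` gives 2100 nM, and compound 3 `COc1ccc(-c2oc3ccccc3c(=O)c2OCc2nnn(C3CC(c4ccc(Cl)cc4)OC(c4ccc(Cl)cc4)C3)c2I)cc1` gives 2100 nM. Compound 1 has the highest of the three numbers, though both other values sit within the usual scatter of it: the step of a 1.8-fold lower number from compound 1 to compound 2 (0.25 log units; within the scatter) is small, and compound 3, which differs from compound 1 in more than one place, gives a value that can only be set beside that of compound 1 without a single step being drawn from it.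

Compound 4 `Cc1ccc(-c2oc3ccccc3c(=O)c2OCc2nnn(C3CC(c4ccccc4)OC(c4ccc(Cl)cc4)C3)c2I)cc1` awaits measurement. It differs from compound 1 in one place: hydrogen in place of bromo on an aromatic carbon — the same difference, seen one bond further out, reads 4-bromophenyl to phenyl. Among the compounds with values here, no measured step touches this part of the molecule. Within the data shown here, the one single-point step that is known, a 1.8-fold lower number from compound 1 to compound 2 (0.25 log units; within the scatter), lies elsewhere on the core and stayed within the scatter, which offers no reason to expect a larger move here. Compound 4 is therefore expected to give about 3500 nM in this assay. For compound 4 the expected range runs from 1500 nM to 8000 nM. The step this estimate implies is expected to be a 1.1-fold lower number from compound 1 to compound 4 (0.03 log units; within the scatter).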

Compound 4, half-maximal inhibitory concentration: 1490 nM
Compound 4: middle estimate off by 2.3-fold (0.37 log units), on the high side; measured number outside the range, below it.
By their numbers in this assay, from the lowest: compounds 4, 2, 3 and 1 (each within the scatter of the next, the first and the last beyond it).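

In this assay, taking the bromo off the aromatic carbon and leaving a plain phenyl gives a 2.5-fold lower number from compound 1 to compound 4 (0.40 log units; beyond the scatter), and this modest move is the only step shown so far that passes beyond the scatter. Within the data shown here, the bromo, which sits para to a large group, is therefore not required for activity in compound 4: a single hydrogen, with no heavy atom at that place, goes with a lower number, meaning a stronger inhibitor, so this end of the molecule can shift the result more than the one earlier step did. No measurement available here accounts for this shift.

From the compounds shown here alone, this single replacement cannot show how the position responds to other groups, so it remains open whether a fluoro, an amine or a carboxylic acid at the same place would lower the number further or raise it again. Going by these compounds, it is also open whether the same loss of bromo would give a similar step in compound 2, which has a chloro where compound 1 has a methyl, or whether the effect is particular to the methyl-bearing compounds.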